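This account rests on a few compounds, and the source may have more. Where it says the series, first, only, none or still open, it means among the compounds named here.

In a functional assay on SK-MEL-28 cells (Homo sapiens) for cytotoxicity, read by CCK-8 assay, with a stated time of 24 h (on this read-out higher numbers stand for weaker inhibition and lower numbers for stronger inhibition), compound 1 `COc1ccccc1Oc1c(N)nc(-c2ccccc2)nc1Cl` gives 3140 nM and is the only numbered point so far. Compound 2 `COc1ccccc1Oc1c(N)nc(-c2ccccc2)nc1OCCO` gives > 80000 nM as a limit of the assay and not a number. Compound 2 is therefore placed only by the limit of > 80000 nM in this assay, at which 1 of the 2 values shown sits, and has no exact position.

Compound 3 `COc1ccccc1Oc1c(N)nc(-c2ccc(C)cc2)nc1OCCO` differs from compound 2 by methyl in place of hydrogen on an aromatic carbon in the change from phenyl to 4-methylphenyl. Within the data shown here, one measured step bears on it only indirectly: an at least 25-fold higher number from compound 1 to compound 2 (1.40 log units; beyond the scatter) with 2-hydroxyethoxy in place of chloro on an aromatic carbon. Compound 3 keeps that 2-hydroxyethoxy group. Among the measured compounds shown here, no measured step covers the methyl, so no step beyond the scatter is expected in this assay, and another limit is possible. The expected change is a number no higher from compound 2 to compound 3 (the limit leaves the size open) on this estimate. For compound 3 the estimated value is 80000 nM with an expected range from 30000 nM to 200000 nM in this estimate.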

Compound 3, half-maximal inhibitory concentration: 6190 nM
Compound 3: middle estimate off by 13-fold (1.11 log units), on the high side, outside the stated range (below it).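

In this assay the phenyl ring, which stayed the same in compound 1 and compound 2, proves to be a sensitive place: methyl in place of hydrogen on an aromatic carbon, para to a large group, returns the 2-hydroxyethoxy compound to a measured value (an at least 12-fold lower number from compound 2 to compound 3 (1.11 log units; beyond the scatter)). The loss seen with 2-hydroxyethoxy in place of chloro is therefore not fixed by that group alone, since a single added carbon on the phenyl ring changes the outcome. From the compounds shown here alone, the true size of this step stays unknown, as compound 2 is placed only by a limit of the assay: the limit of > 80000 nM in this assay, at which 1 of the 3 values shown sits.

Going by these compounds, whether the same methyl change gives a comparable step with chloro in place of 2-hydroxyethoxy remains open. Also open, on these data alone, is how an ethyl, a methoxy or a carboxylic acid would read in place of that methyl.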